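The compounds below may be only part of what the source reports. "The series", "measured", "known", "first", "only" and "open" are said of these compounds alone.

Compound 1 `CC(=O)NCC(=O)Nc1ccc(Cl)cc1C(=O)c1ccccc1`: > 100 mg/kg
Compound 2 `CN(C(=O)CNC(=O)CN1CCCCC1)c1ccc(Cl)cc1C(=O)c1ccccc1Cl`: > 100 mg/kg

Both compounds were tested in a functional assay on the whole organism with Mus musculus as the target, in the rotarod test; on this read-out higher numbers stand for an effect only at larger amounts of compound and lower numbers for an effect already at smaller amounts. There, compound 1 gives > 100 mg/kg, which is a limit of the assay and not a number. Compound 2 gives > 100 mg/kg, which is also a limit. The measurements so far therefore amount to the limit of > 100 mg/kg in this assay, at which 2 of the 2 values shown sit, and neither compound has a numerical value.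

The next compound, compound 3 `NC(C(=O)NCC(=O)Nc1ccc(Cl)cc1C(=O)c1ccccc1)c1ccccc1`, keeps the core of compound 1 and changes one group: amino(phenyl)methyl in place of methyl on a carbonyl carbon. Amino(phenyl)methyl takes the place of methyl on a carbonyl carbon. For the measured compounds named here, no measured pair shows what this kind of change does in this assay, so the expectation is a cautious one.

Because compound 1 sits at the limit > 100 mg/kg, only a modest step towards smaller amounts is expected, and one no larger than the scatter is quite possible. The expected change is a step that the limit leaves unreadable from compound 1 to compound 3. Compound 3 is estimated at 130 mg/kg. The expected range for this estimate runs from 50 mg/kg to 300 mg/kg. It is more likely than not that the assay will again report only a limit.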

Compound 3, dose for half-maximal effect: > 100 mg/kg
Compound 3 ended at the assay's limit (the forecaster's own chance of this, stated with the estimate: 65%); the middle value does not contradict the limit.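

In this assay compound 3 gives > 100 mg/kg as a limit of the assay and not a number. For the compounds shown here, no step from compound 1 to compound 3 can be read, because the comparison rests on two limits: the limit of > 100 mg/kg in this assay, at which 3 of the 3 values shown sit. The compounds shown leave open whether amino(phenyl)methyl in place of methyl on a carbonyl carbon changes the read-out at all.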